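A fluorophenyl for a chlorophenyl: expected seizure protection

The source may report more compounds than this note shows. Statements on the series, on what has been measured and on what is new or still open speak of the compounds shown alone.

Compound 2 `CC(C(=O)N1CCN(c2ccc(Cl)cc2)CC1)N1C(=O)CCC1=O` gives 100% in a functional assay on the whole organism (strain Swiss) with Mus musculus as the target, in the maximal electroshock model, with a stated time of 0.5 h, at a dose of 300 mg/kg by the intraperitoneal route (on this read-out lower numbers stand for a weaker effect and higher numbers for a stronger effect at the one dose given), the highest of the three numbers measured. Compound 3 `CC(C(=O)N1CCN(c2ccc(C(F)(F)F)cc2)CC1)N1C(=O)CCC1=O` gives 25%, and compound 1 `CCC(C(=O)N1CCN(c2ccc(Cl)cc2)CC1)N1C(=O)CCC1=O` gives 0%. The step of a number 100 percentage points higher from compound 1 to compound 2 (beyond the scatter) and the step of a number 75 percentage points lower from compound 2 to compound 3 (beyond the scatter) are both large. Compound 4 `CC(C(=O)N1CCN(c2cccc(F)c2)CC1)N1C(=O)CCC1=O` differs from compound 2 by 3-fluorophenyl in place of 4-chlorophenyl on an amine nitrogen in a ring. Of the measured steps, a number 75 percentage points lower from compound 2 to compound 3 (beyond the scatter) bears most directly on this change: it too replaced the aryl group on the amine nitrogen in a ring, and it was large. A further change of that aryl group is therefore expected to lower the number in this assay, with a step of a number 50 percentage points lower from compound 2 to compound 4 (beyond the scatter) expected. Compound 4 is accordingly estimated at 50%, between 10% and 90%.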

Compound 4, a percentage reported as activity, at one dose (the size of the read-out at that dose, not a potency): 50%
Compound 4: middle estimate and measured number agree at the digits printed, and the stated range covers the measured number.
By their numbers in this assay, from the lowest: compound 1; then compound 3; then compound 4; then compound 2.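

In this assay, the step of a number 50 percentage points lower from compound 2 to compound 4 (beyond the scatter) shows that the aryl group on the amine nitrogen in a ring can lose its chlorine and still retain part of the effect at this dose. This single change alters both the halogen and its place on the ring, so the step cannot be assigned to either alone. No measurement at hand bears on its cause. The compounds shown leave open how 3-chlorophenyl, 4-fluorophenyl or unsubstituted phenyl would behave on that nitrogen, and therefore which part of the change carries the step.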